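Switching the anilino ring of compound 3 from methoxy to chloro

This account rests on a few compounds, and the source may have more. Where it says the series, first, only, none or still open, it means among the compounds named here.

Measured so far in a functional assay on MCF7 cells (Homo sapiens) for inhibition, read by MTT assay, with a stated time of 72 h; a lower number here means a stronger inhibitor, a higher number a weaker inhibitor:
compound 1 `C#CCSc1nc(Nc2ccc(Cl)cc2)c(C#N)c(-c2ccccc2)n1` gives > 128000 nM, a limit of the assay
compound 2 `C#CCSc1nc(Nc2cccc(Cl)c2)c(C#N)c(-c2ccccc2)n1` gives > 128000 nM, a limit of the assay
compound 3 `COc1ccc(Nc2nc(SCc3cn(Cc4ccccc4Cl)nn3)nc(-c3ccccc3)c2C#N)cc1` gives 8050 nM

Going by the values given here, compound 3 is the only member of the series with a numerical read-out in this assay. Compound 1 sits at a limit, as noted in the list. Compound 2 sits at the same limit. Among the compounds with values here, the one step between measured neighbours, a step that the two limits leave unreadable from compound 1 to compound 2, therefore cannot be sized; both ends rest on (the limit of > 128000 nM in this assay, at which 2 of the 3 values shown sit).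

Compound 4 `N#Cc1c(Nc2ccccc2Cl)nc(SCc2cn(Cc3ccccc3Cl)nn2)nc1-c1ccccc1` differs from compound 3 by 2-chlorophenyl in place of 4-methoxyphenyl on a nitrogen on an aromatic ring. Within the data shown here, no measured pair changes the same aryl group while keeping the rest of the core of compound 3, and the pair of compound 1 and compound 2, which alters a chloro position on the same kind of aryl group, gives no readable size. Nothing measured here therefore points to a step in this assay beyond the scatter in either direction, and the expectation for compound 4 leans on the value of compound 3 alone, widened for the untested change.

Compound 4 is accordingly expected to give about 12000 nM in this assay, within 3000 nM to 60000 nM, which amounts to an expected step of a 1.5-fold higher number from compound 3 to compound 4 (0.17 log units; within the scatter).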

Compound 4, half-maximal inhibitory concentration: 1950 nM
Compound 4: middle estimate off by 6.2-fold (0.79 log units), on the high side; measured number below the stated range.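

In this assay, the nitrogen-bound aryl group on the core of compound 3 proves to be a place where the read-out moves: going from (4-methoxyphenyl)amino to (2-chlorophenyl)amino gives a 4.1-fold lower number from compound 3 to compound 4 (0.62 log units; beyond the scatter). Going by these compounds alone, this is the first step that can be sized, and it shows that the series can move toward a lower number at this position while the rest of the core stays fixed. Nothing measured here accounts for the step.

The change replaces both the substituent and its place on the ring in one move, so the compounds shown do not separate the two, and it stays open how 2-methoxyphenyl, 4-chlorophenyl or an aryl group carrying an amine or a carboxylic acid would read on this same core. The step between compound 1 and compound 2, the only other pair that moves a chloro group, cannot be read, and it offers no guide for this core, since both ends rest on a limit: the limit of > 128000 nM in this assay, at which 2 of the 4 values shown sit.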